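The source may hold more compounds than are shown below. What is called first, only, known or untested is meant among the compounds shown, and "the series" means these compounds.

Measured so far in an ADME assay on microsomes from liver (Homo sapiens) for pharmacokinetics, read by LC-MS, with a stated time of 60 min, tested at 1 uM; a higher number here means faster removal of the compound, a lower number slower removal:
- compound 1 `O=C(NCc1ccc(S(=O)(=O)c2ccccc2)cc1)N1Cc2ccncc2C1` gives 7.5 mL/min/kg
- compound 2 `CC(C)n1cc(S(=O)(=O)c2ccc(CNC(=O)N3Cc4ccncc4C3)cc2)cn1` gives 4 mL/min/kg
- compound 3 `O=C(NCc1ccc(S(=O)(=O)C2CCCCC2)cc1)N1Cc2ccncc2C1` gives 16 mL/min/kg

Compound 2 stands lowest of the three numbers. Its nearest neighbour is compound 1, within the scatter, and its furthest is compound 3, beyond the scatter. Compound 4 `CN1CCC(S(=O)(=O)c2ccc(CNC(=O)N3Cc4ccncc4C3)cc2)CC1` has not yet been run. Its difference from compound 2 is: 1-methylpiperidin-4-yl in place of 1-isopropyl-1H-pyrazol-4-yl on a sulfonyl sulfur.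

Of the measured steps, a 4.0-fold higher number from compound 2 to compound 3 (0.60 log units; beyond the scatter) is the closest parallel: it too exchanges the 1-isopropyl-1H-pyrazol-4-yl on the sulfonyl sulfur for a six-membered non-aromatic ring. The step of a 2.1-fold higher number from compound 1 to compound 3 (0.33 log units; beyond the scatter) points the same way, while a 1.9-fold lower number from compound 1 to compound 2 (0.27 log units; within the scatter) stays within the scatter. On this footing a modest rise in this assay is expected for compound 4, in the direction of compound 3. The size is uncertain, as the entering 1-methylpiperidin-4-yl is not the cyclohexyl of compound 3, so the range is set wide. The expected step is a 2.5-fold higher number from compound 2 to compound 4 (0.40 log units; beyond the scatter). Compound 4 is estimated at 10 mL/min/kg, with a range from 4 mL/min/kg to 25 mL/min/kg.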

Compound 4, clearance: 11 mL/min/kg
Beside the measured number, compound 4's estimate is 1.1-fold (0.04 log units) below it, within the range that was stated.
By their numbers in this assay, from the lowest: compounds 2, 1, 4 and 3 (each within the scatter of the next, the first and the last beyond it).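

In this assay the sulfonyl sulfur takes 1-methylpiperidin-4-yl with a clear move away from the 1-isopropyl-1H-pyrazol-4-yl of the earlier low point, as a 2.8-fold higher number from compound 2 to compound 4 (0.44 log units; beyond the scatter) shows, so this position responds to a change that swaps the five-membered aromatic ring for a six-membered non-aromatic ring holding a hetero atom as well as to the all-carbon cyclohexyl exchange seen before. A ring nitrogen carrying a methyl group does not separate the ring from cyclohexyl here (a 1.5-fold lower number from compound 3 to compound 4 (0.16 log units; within the scatter)), and the same substituent also stays unresolved from phenyl (a 1.5-fold higher number from compound 1 to compound 4 (0.17 log units; within the scatter)), which leaves the step from compound 2 as the only one of the three beyond the scatter. No data on hand account for any of these steps.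

Open, on these data alone, is whether the rise belongs to losing the 1-isopropyl-1H-pyrazol-4-yl specifically or to losing aromaticity at the sulfonyl sulfur, which a simpler 1-methylpyrazol-4-yl or a pyridin-3-yl would help to separate. Equally open is what the methyl on the piperidine contributes, since neither a piperidine without it, nor a tetrahydropyran-4-yl, nor a ring bearing a carboxylic acid appears among these compounds.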